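Amide in place of sulfonamide on the aryl sulfonyl

A few compounds are considered here, and "the series" means these few. Any claim that something is new, unique, unknown or untested is made for them only; others in the source may bear on it.

Compound 1 `CCOC(=O)[C@@H]1CCCN(S(=O)(=O)c2ccc(S(=O)(=O)N3CCOCC3)cc2)C1` carries a morpholin-4-yl on the sulfonyl sulfur and gives 4100 nM in a functional assay on MIA PaCa-2 cells (Homo sapiens) for inhibition, read by MTT assay, with a stated time of 3 days; on this read-out higher numbers stand for weaker inhibition and lower numbers for stronger inhibition. Compound 2 `CCOC(=O)[C@@H]1CCCN(S(=O)(=O)c2ccc(S(=N)(=O)N(CC)CC)cc2)C1` gives 900 nM in this assay, and compound 3 `CCOC(=O)[C@@H]1CCCN(S(=O)(=O)c2ccc(S(=O)(=O)N(CC)C(C)C)cc2)C1` gives 1200 nM. Compound 3 therefore holds the second highest of the three numbers: against compound 2 the difference is a 1.3-fold higher number from compound 2 to compound 3 (0.12 log units; within the scatter), while against compound 1 it is a 3.4-fold lower number from compound 1 to compound 3 (0.53 log units; beyond the scatter). The remaining measured step is a 4.6-fold lower number from compound 1 to compound 2 (0.66 log units; beyond the scatter).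

Compound 4 `CCOC(=O)[C@@H]1CCCN(S(=O)(=O)c2ccc(C(=O)N(CC)CC)cc2)C1` differs from compound 3 by diethylcarbamoyl in place of ethyl(isopropyl)sulfamoyl on an aromatic carbon. Going by the values given here, no measured step exchanges a sulfamoyl for a carbamoyl, so none bears on this change directly. The nearest comparisons keep a sulfur-based group throughout: a 1.3-fold higher number from compound 2 to compound 3 (0.12 log units; within the scatter) lies within scatter, and a 3.4-fold lower number from compound 1 to compound 3 (0.53 log units; beyond the scatter) is modest. With the open-chain amine retained and only the linking group altered, the step from compound 3 to compound 4 is expected to be a 1.5-fold higher number from compound 3 to compound 4 (0.18 log units; within the scatter), most likely not beyond the scatter. Compound 4 is accordingly estimated at 1800 nM, with a range from 600 nM to 5500 nM.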

Compound 4, half-maximal inhibitory concentration: 100 nM
The estimate for compound 4 lay 18-fold (1.26 log units) above the measured number, and the stated range ends above it.
By their numbers in this assay, from the lowest: compound 4; then compounds 2 and 3 (each within the scatter of the next); then compound 1.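

Against the sulfur-linked groups, the steps of a 12-fold lower number from compound 3 to compound 4 (1.08 log units; beyond the scatter) and a 9.0-fold lower number from compound 2 to compound 4 (0.95 log units; beyond the scatter) and a 41-fold lower number from compound 1 to compound 4 (1.61 log units; beyond the scatter) are all beyond the scatter, so compound 4 holds the lowest number of the four in this assay at this position. On this aromatic carbon, para to a large group, a sulfur atom in the linking group is therefore not required for inhibition, and a carbonyl-linked group is accepted. Nothing on hand explains the size of this change.

Going by these compounds, the step from compound 3 to compound 4 alters the link and the amine together, so the share of each stays open; ethyl(isopropyl)carbamoyl or diethylsulfamoyl would separate them. Also open, on these data alone, is whether morpholin-4-ylcarbonyl or ethylcarbamoyl, with its amide hydrogen, would keep the low number.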